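This account rests on a few compounds, and the source may have more. Where it says the series, first, only, none or still open, it means among the compounds named here.

Working notes on the aryl variation at the carbon with a double bond to nitrogen, with the shared core held constant throughout.

Compound 1 `CN(C)CCn1cnnc1-c1cc(Oc2ccc(NC(=O)N/N=C/c3ccc(Cl)cc3Cl)cc2F)ccn1` gives 390 nM in a functional assay on HT-29 cells (Homo sapiens) for cytotoxicity, read by MTT assay, with a stated time of 72 h; a lower number here means a stronger inhibitor, a higher number a weaker inhibitor. Compound 2 `CN(C)CCn1cnnc1-c1cc(Oc2ccc(NC(=O)N/N=C/c3ccccc3O[N+](=O)[O-])cc2F)ccn1` gives 950 nM in this assay, and compound 3 `CN(C)CCn1cnnc1-c1cc(Oc2ccc(NC(=O)N/N=C/c3c(O)ccc4ccccc34)cc2F)ccn1` gives 670 nM in this assay. Among the three numbers compound 3 stands second highest; its nearest neighbour is compound 2, with a 1.4-fold lower number from compound 2 to compound 3 (0.15 log units; within the scatter), and its furthest is compound 1, with a 1.7-fold higher number from compound 1 to compound 3 (0.24 log units; within the scatter), both within the scatter. For the measured compounds named here, the only step beyond the scatter in the set is a 2.4-fold higher number from compound 1 to compound 2 (0.39 log units; beyond the scatter), and that one is modest.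

Compound 4 `CN(C)CCn1cnnc1-c1cc(Oc2ccc(NC(=O)N/N=C/c3cccc(O)c3)cc2F)ccn1` has not yet been measured. Its change from compound 3 is 3-hydroxyphenyl in place of 2-hydroxynaphthalen-1-yl on a carbon with a double bond to nitrogen. All three measured steps bear on this, since each of them also exchanges the aryl group on the carbon with a double bond to nitrogen, and none of them moved the number by more than a modest amount. A step within the scatter is therefore expected in this assay, with no clear direction.

Compound 4 is expected to give about 750 nM, within a range of 350 nM to 1600 nM. The expected step is a 1.1-fold higher number from compound 3 to compound 4 (0.05 log units; within the scatter).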

Compound 4, half-maximal inhibitory concentration: 330 nM
The estimate for compound 4 lay 2.3-fold (0.36 log units) above the measured number; the measured number lies below the stated range.
By their numbers in this assay, from the lowest: compounds 4, 1, 3 and 2 (each within the scatter of the next, the first and the last beyond it).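

In this assay, 3-hydroxyphenyl on the carbon with a double bond to nitrogen gives a 2.0-fold lower number from compound 3 to compound 4 (0.31 log units; beyond the scatter), so this position can separate two hydroxyl-bearing aryl groups by more than the scatter, which neither earlier step involving compound 3 had shown. The same group gives a 2.9-fold lower number from compound 2 to compound 4 (0.46 log units; beyond the scatter), a second modest step beyond the scatter that moves away from the 2-(nitrooxy)phenyl compound, whereas a 1.2-fold lower number from compound 1 to compound 4 (0.07 log units; within the scatter) leaves 3-hydroxyphenyl and 2,4-dichlorophenyl indistinguishable here, and the smaller single-ring group is thus tolerated at this position without any loss against compound 1. No measured information on these compounds accounts for these differences.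

The compounds shown leave open whether the step from compound 3 belongs to the second six-membered aromatic ring that leaves or to the place of the hydroxyl, since both change together in this one exchange. They also leave open how 4-hydroxyphenyl, or a phenyl ring carrying an amine or a carboxylic acid, would read on this carbon with the shared core held constant.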